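The compounds below may be only part of what the source reports. "The series", "measured", "known", "first", "only" and "open" are said of these compounds alone.

Measured so far:
compound 1 `COc1ccc(CNCCCNS(=O)(=O)c2cc(C(F)(F)F)cc(C(F)(F)F)c2)cc1OC` — 3500 nM
compound 2 `COc1cccc(CNCCCNS(=O)(=O)c2cc(C(F)(F)F)cc(C(F)(F)F)c2)c1` — 2400 nM

In a functional assay on HPAC cells (Homo sapiens) for inhibition, read by MTT assay, with a stated time of 72 h (on this read-out lower numbers stand for stronger inhibition of growth and higher numbers for weaker inhibition of growth), compound 1 gives 3500 nM and compound 2 gives 2400 nM. Within the data shown here, compound 2 holds the lowest of the two numbers, but the only step between them, a 1.5-fold lower number from compound 1 to compound 2 (0.16 log units; within the scatter), is within the scatter, so the two are not distinguished by these data.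

Compound 3 `O=S(=O)(NCCCNCc1ccccc1Cl)c1cc(C(F)(F)F)cc(C(F)(F)F)c1` differs from compound 2 as follows: 2-chlorophenyl in place of 3-methoxyphenyl on a saturated chain carbon bound to an amine nitrogen.

Among the measured compounds shown here, the single measured step bears on this only loosely: it covers loss of a methoxy on an aromatic carbon of the benzyl part, and it was within the scatter. For the measured compounds named here, no measured step covers a chlorine entering, or a change from 3-substituted to 2-substituted benzyl. On the evidence of a 1.5-fold lower number from compound 1 to compound 2 (0.16 log units; within the scatter), changes on this ring have not moved the number beyond the scatter, so no step beyond the scatter is expected in this assay for compound 3 either, with the range kept wide for the untested change.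

Compound 3 is therefore estimated at 2400 nM, with a range of 800 nM to 7000 nM, meaning an expected step of no change at the digits printed from compound 2 to compound 3 (within the scatter).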

Compound 3, concentration for 50% growth inhibition: 10000 nM
For compound 3 the middle estimate is 4.2-fold (0.62 log units) below the measured one, and the stated range ends below it.
By their numbers in this assay, from the lowest: compounds 2 and 1 (each within the scatter of the next); then compound 3.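

In this assay, the aryl group on the saturated chain carbon bound to an amine nitrogen is now shown to affect the number: 2-chlorophenyl in place of 3-methoxyphenyl gives a 4.2-fold higher number from compound 2 to compound 3 (0.62 log units; beyond the scatter), and 2-chlorophenyl in place of 3,4-dimethoxyphenyl gives a 2.9-fold higher number from compound 1 to compound 3 (0.46 log units; beyond the scatter). The earlier pair showed no such effect, as a 1.5-fold lower number from compound 1 to compound 2 (0.16 log units; within the scatter) left compounds 1 and 2 undistinguished, so this position is not indifferent to every aryl group, although both new steps are modest. Nothing available gives a reason for the higher number of compound 3.

Chlorine replaces methoxy and the substituent's place on the ring changes within the same swap, so the compounds shown leave open which of the two goes with the higher number. Unsubstituted phenyl at this position would be the plainest reference for both, and whether a group such as nitrile or trifluoromethyl on this ring would follow compound 3 or stay with compounds 1 and 2 also remains open.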